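A Symmetric Pair of Chlorothiophene Sulfonamides

A few compounds are considered here, and "the series" means these few. Any claim that something is new, unique, unknown or untested is made for them only; others in the source may bear on it.

Of the compounds shown here, two sharing one core have been measured in an assay for inhibition of HSP60/HSP10 (Homo sapiens), with a stated time of 60 min; on this read-out lower numbers stand for stronger inhibition and higher numbers for weaker inhibition. Compound 1 `O=[N+]([O-])c1cc(S(=O)(=O)Nc2ccc(-c3nc4cc(NS(=O)(=O)c5ccc(Cl)s5)ccc4o3)cc2)ccc1Cl` gives 2100 nM in this assay. Compound 2 `O=S(=O)(Nc1ccc2oc(-c3ccc(NS(=O)(=O)c4ccc(Cl)s4)cc3)nc2c1)c1cccc(C(F)(F)F)c1` gives 5000 nM in this assay, the higher of the two numbers, and the gap between compound 1 and compound 2 lies beyond the usual scatter of repeated measurements. Compound 3 `O=S(=O)(Nc1ccc(-c2nc3cc(NS(=O)(=O)c4ccc(Cl)s4)ccc3o2)cc1)c1ccc(Cl)s1` has not yet been measured. It differs from compound 2 in one place: 5-chlorothiophen-2-yl in place of 3-(trifluoromethyl)phenyl on a sulfonyl sulfur. After this change both sulfonyl groups of compound 3 carry the same 5-chlorothiophen-2-yl group. For the measured compounds named here, no measured pair shows what such a change does, so the expected step from compound 2 to compound 3 is a 2.0-fold lower number from compound 2 to compound 3 (0.30 log units; within the scatter), a modest move toward a lower number, within a range that also allows no change beyond the scatter. Compound 3 is therefore expected to give about 2500 nM in this assay, between 900 nM and 7000 nM.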

Compound 3, half-maximal inhibitory concentration: 5900 nM
Compound 3: the middle estimate sits 2.4-fold (0.37 log units) below what was measured; low and high end bracket the measured number.
By their numbers in this assay, from the lowest: compound 1; then compounds 2 and 3 (each within the scatter of the next).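

In this assay, putting 5-chlorothiophen-2-yl in place of 3-(trifluoromethyl)phenyl on this sulfonyl sulfur gives a 1.2-fold higher number from compound 2 to compound 3 (0.07 log units; within the scatter) and thus no difference beyond the scatter, even though both sulfonyl groups now carry the same group. Putting it in place of 4-chloro-3-nitrophenyl gives a 2.8-fold higher number from compound 1 to compound 3 (0.45 log units; beyond the scatter) and this is a modest loss, so the group on this sulfur can shift the number, though only the 4-chloro-3-nitrophenyl group stands apart so far. Nothing available explains this difference.

The compounds shown leave open what a group of another kind on this sulfur would do, such as a phenyl ring bearing a carboxylic acid or an amine. They also leave open the role of the other sulfonyl group, which carries 5-chlorothiophen-2-yl in all three compounds.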